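This account rests on a few compounds, and the source may have more. Where it says the series, first, only, none or still open, it means among the compounds named here.

Measured in a functional assay on A549 cells (Homo sapiens) for inhibition, read by colorimetric assay and MTT assay, with a stated time of 72 h; a higher number here means a weaker inhibitor, a lower number a stronger inhibitor:

- Compound 1 `COc1ccccc1-c1cnc(OCC(F)(F)C(F)(F)C(F)(F)C(F)(F)C(F)(F)F)n1C` gives 83000 nM
- Compound 2 `COc1ccccc1-c1cnc(OC)n1C` gives > 100000 nM (a limit, not a number)
- Compound 3 `C=CCCCCOc1ccccc1-c1cnc(OC)n1C` gives 80000 nM

Compound 2 has no number, only a limit: the limit of > 100000 nM in this assay, at which 1 of the 3 values shown sits.

Compound 4 `COc1ccccc1-c1cnc(OCCCc2ccccc2)n1C` has phenethyl in place of hydrogen on a saturated chain carbon bound to an oxygen on an aromatic ring.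

Going by the values given here, the one measured step of this kind is an at least 1.2-fold lower number from compound 2 to compound 3 (0.09 log units; that floor lies within the scatter), with pent-4-en-1-yl as the entering group. Compound 1 and compound 3 have values within the scatter of each other. In this assay only a small move to a lower number is therefore expected, and it may not clear the scatter.

The expected step is an at least 1.4-fold lower number from compound 2 to compound 4 (0.15 log units; that floor lies within the scatter). The estimate for compound 4 is 70000 nM, within an expected range of 30000 nM to 100000 nM.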

Compound 4, half-maximal inhibitory concentration: 3000 nM
The estimate for compound 4 lay 23-fold (1.37 log units) above the measured number; measured number below the stated range.
By their numbers in this assay, from the lowest: compound 4; then compounds 3 and 1 (each within the scatter of the next). At a limit, above all of these: compound 2.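

In this assay, phenethyl at this saturated chain carbon bound to an oxygen on an aromatic ring gives an at least 33-fold lower number from compound 2 to compound 4 (1.52 log units; beyond the scatter). The step with pent-4-en-1-yl, an at least 1.2-fold lower number from compound 2 to compound 3 (0.09 log units; that floor lies within the scatter), showed no such gain, and compound 1, with its fluorinated chain, gives 83000 nM, so a large response here appears with the entering aromatic ring of compound 4. Compound 2 has a limit and not a number, so this step is only a floor: the limit of > 100000 nM in this assay, at which 1 of the 4 values shown sits.

On these data alone, it remains open whether the aromatic ring itself is needed, or whether a cyclohexyl ring would serve as well. Also open, as far as these compounds go, is how a longer chain ending in phenyl would behave.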